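The source may report more compounds than this note shows. Statements on the series, on what has been measured and on what is new or still open speak of the compounds shown alone.

Measured compounds:
- compound 1, `CC(=O)c1ccc(COc2ccc(-c3nn[nH]n3)cc2)c(C)c1O`, 100 nM
- compound 2, `CCCc1c(COc2ccc(-c3nn[nH]n3)cc2)ccc(C(C)=O)c1O`, 10 nM

In a functional assay on ileum (Cavia porcellus) for inhibition of cysteinyl leukotriene receptor (Homo sapiens) (on this read-out lower numbers stand for stronger inhibition and higher numbers for weaker inhibition), compound 1 gives 100 nM, and compound 2 gives 10 nM. Compound 2 therefore has the lowest number of the two measured compounds, and the only other one, compound 1, sits at a higher number. Among the compounds with values here, the single step that has been measured, a 10-fold lower number from compound 1 to compound 2 (1.00 log units; beyond the scatter), came from one change: ethyl in place of hydrogen on a saturated chain carbon bound to an aromatic carbon, which lengthens the chain on the shared core.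

Compound 3, `CCCCc1c(COc2ccc(-c3nn[nH]n3)cc2)ccc(C(C)=O)c1O`, carries the same change one bond further along: methyl in place of hydrogen on a saturated chain carbon, three bonds along the chain from an aromatic carbon, so that the chain reads propyl to butyl. The measured step from compound 1 to compound 2 shows that lengthening this chain lowered the number, but that step added two carbons right at the core, whereas here one carbon is added at the far end. A smaller gain, or no change beyond the scatter, is the more cautious expectation in this assay. Compound 3 is therefore estimated at 6 nM, with a range from 2 nM to 25 nM. This estimate means a step of a 1.7-fold lower number from compound 2 to compound 3 (0.22 log units; within the scatter).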

Compound 3, half-maximal inhibitory concentration: 12.6 nM
For compound 3 the middle estimate is 2.1-fold (0.32 log units) below the measured one; the measured number falls inside the stated range.
By their numbers in this assay, from the lowest: compounds 2 and 3 (each within the scatter of the next); then compound 1.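

Going from propyl to butyl at this position, three bonds along the chain from an aromatic carbon, gives a 1.3-fold higher number from compound 2 to compound 3 (0.10 log units; within the scatter) in this assay and so leaves compound 2 and compound 3 level, which the single earlier step could not show. Both longer chains stand clear of the methyl of compound 1: the earlier step was a 10-fold lower number from compound 1 to compound 2 (1.00 log units; beyond the scatter) and the new comparison is a 7.9-fold lower number from compound 1 to compound 3 (0.90 log units; beyond the scatter), so among these three compounds the number falls once from methyl to propyl and then stays flat when one more carbon is added, rather than falling with each added carbon. No measurement available here explains why the chain's extra carbon makes no visible difference.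

The ethyl chain would show where between methyl and propyl the drop happens, and a pentyl or hexyl chain would show whether the number stays level, rises or falls further as the chain grows. From the compounds shown here alone, it also remains open how this position responds to something other than a plain carbon chain, such as a chain ending in an amine or a carboxylic acid, or a benzyl group.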